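A benzyl ring swap on an inactive scaffold

A few compounds are considered here, and "the series" means these few. Any claim that something is new, unique, unknown or untested is made for them only; others in the source may bear on it.

Compound 2 (`Cc1ccccc1Cn1cc(COc2ccc3c(=O)ccoc3c2)nn1`) was tested in a functional assay on MDA-MB-231 cells (Homo sapiens) for cytotoxicity, read by MTT assay, with a stated time of 48 h (on this read-out lower numbers stand for stronger inhibition and higher numbers for weaker inhibition), and in that test compound 2 gives only a limit, > 100000 nM. Its closest relative, compound 1 (`Cc1ccc(Cn2cc(COc3ccc4c(=O)ccoc4c3)nn2)cc1`), carries 4-methylphenyl instead of 2-methylphenyl on a saturated chain carbon bound to an aromatic nitrogen. In this assay compound 1 likewise gives only a limit, > 100000 nM. The step that the two limits leave unreadable from compound 1 to compound 2 therefore cannot be read, because of the limit of > 100000 nM in this assay, at which 2 of the 2 values shown sit. Compound 3 (`O=c1ccoc2cc(OCc3cn(Cc4cccc(F)c4)nn3)ccc12`) is the next point: 3-fluorophenyl in place of 2-methylphenyl on a saturated chain carbon bound to an aromatic nitrogen. Among the compounds with values here, only the one step between compound 1 and compound 2 bears on this change, and since its size is not readable, it gives no direction and no size to carry over. The step of a number no higher from compound 2 to compound 3 (the limit leaves the size open) is expected to stay within the scatter of the measurement. Compound 3 is expected once more to sit at the limit of this assay rather than to yield a number. Compound 3 is estimated at 100000 nM, with a likely range from 30000 nM to 300000 nM.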

Compound 3, half-maximal inhibitory concentration: > 100000 nM
Compound 3: no number, only a limit; the forecaster's own chance of this, stated with the estimate: 80%; the middle value sits exactly at the limit.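

Compound 3, like compound 1 and compound 2, gives only a limit in this assay, so the steps from either of them to compound 3 cannot be read: the limit of > 100000 nM in this assay, at which 3 of the 3 values shown sit.

The compounds shown leave open whether the 4-methylphenyl, 2-methylphenyl and 3-fluorophenyl groups differ at all in this assay, and what change to the shared core would yield a true number.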